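Moving the Chlorine Around the Phenyl Ring

A few compounds are considered here, and "the series" means these few. Any claim that something is new, unique, unknown or untested is made for them only; others in the source may bear on it.

Compound 1 `Fc1ccc2c(c1)CCC(c1nnc(-c3cn(Cc4c(F)cccc4F)nn3)o1)O2`: 88000 nM in a functional assay; a higher number here means a weaker inhibitor, a lower number a stronger inhibitor
Compound 2 `Fc1ccc2c(c1)CCC(c1nnc(-c3cccc(Cl)c3)o1)O2`: 84800 nM in this assay

Both compounds share the same core and differ only in the group attached to the five-membered ring. Compound 2 shows the lower of the two numbers, but compound 1 lies within the usual scatter of it, so the two cannot be told apart on these data alone; both are weak inhibitors.

Compound 3 `Fc1ccc2c(c1)CCC(c1nnc(-c3ccccc3Cl)o1)O2` keeps every atom of compound 2 and changes only where the chlorine sits on the phenyl ring: 2-chlorophenyl in place of 3-chlorophenyl on an aromatic carbon. Going by the values given here, no measured pair in this set shows what such a move does, so there is no step to lean on. The expectation is a shift no larger than the scatter, in no particular direction, estimated as a 1.0-fold higher number from compound 2 to compound 3 (0.00 log units; within the scatter). Compound 3 is therefore expected to give 85000 nM, with a range from 30000 nM to 250000 nM.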

Compound 3, half-maximal inhibitory concentration: 88000 nM
The estimate for compound 3 lay 1.0-fold (0.02 log units) below the measured number, and the stated range covers the measured number.
By their numbers in this assay, from the lowest: compounds 2, 1 and 3 (each within the scatter of the next).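

Swapping 3-chlorophenyl for 2-chlorophenyl gives a 1.0-fold higher number from compound 2 to compound 3 (0.02 log units; within the scatter) in this assay, the first step between two compounds that differ in one place. For this pair, the two chlorine placements on the phenyl ring, which sits on the aromatic carbon of the five-membered ring, cannot be told apart by this read-out. No measurement here bears on why this is so.

Open, as far as these compounds go, is whether a different group on the phenyl ring, such as an amine or a carboxylic acid in place of the chlorine, would give a step beyond the scatter. Also open, from the compounds shown here alone, is whether an unsubstituted phenyl ring at the same place would stay within the scatter of compound 2 and compound 3.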